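Swapping Ethyl for Benzoyl: A Cytotoxicity Forecast

The source may report more compounds than this note shows. Statements on the series, on what has been measured and on what is new or still open speak of the compounds shown alone.

Of the compounds shown here, three built on one shared core have been tested in an ADME assay on PC-3 cells (Homo sapiens) for cytotoxicity, read by WST assay, tested at 100 uM; on this read-out higher numbers stand for more inhibition at the one concentration tested (going by the name of the read-out) and lower numbers for less inhibition. Compound 1 `O=C(Nc1ccc(Cl)cn1)C1CCCN(C(=O)c2cc(C(F)(F)F)cc(C(F)(F)F)c2)C1` gives 0%. Compound 2 `CCc1cccc(NC(=O)C2CCCN(C(=O)c3cc(C(F)(F)F)cc(C(F)(F)F)c3)C2)c1` gives 0%. Compound 3 `O=C(Nc1ccc(Cl)cc1)C1CCCN(C(=O)c2cc(C(F)(F)F)cc(C(F)(F)F)c2)C1` gives 14%. Compound 2 thus stands level with compound 1, the two together at the lowest numbers of the three, while the step of a number 14 percentage points higher from compound 2 to compound 3 (beyond the scatter) and the step of a number 14 percentage points higher from compound 1 to compound 3 (beyond the scatter) set compound 3 modestly apart; the step of no change at the digits printed from compound 1 to compound 2 (within the scatter) lies within the scatter.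

Compound 4 `O=C(c1ccccc1)c1cccc(NC(=O)C2CCCN(C(=O)c3cc(C(F)(F)F)cc(C(F)(F)F)c3)C2)c1` has not yet been measured in this assay. It differs from compound 2 in one place: benzoyl in place of ethyl on an aromatic carbon. The shared core and the amide link stay as they are; only the substituent on the aromatic ring, meta to a large group, is exchanged.

Among the measured compounds shown here, only the step of a number 14 percentage points higher from compound 2 to compound 3 (beyond the scatter) bears directly on this change; it too altered the group on the amide-type nitrogen, and it was modest. The step of no change at the digits printed from compound 1 to compound 2 (within the scatter) shows that two quite different groups there can give the same low reading. The expected step is therefore small, a number 5 percentage points higher from compound 2 to compound 4 (within the scatter), most likely within the scatter. Compound 4 is estimated to give 5%, with a range from 0% to 20%.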

Compound 4, a percentage reported as inhibition, at one concentration (the size of the read-out at that concentration, not a potency): 0%
Estimate against measurement, compound 4: 5 percentage points above; the range from low to high includes it.
By their numbers in this assay, from the lowest: compounds 1, 2 and 4 (each within the scatter of the next); then compound 3.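

In this assay, benzoyl in place of ethyl on this aromatic carbon, meta to a large group, gives no change at the digits printed from compound 2 to compound 4 (within the scatter) and so leaves the reading where it was. The earlier steps shown here exchanged the whole group on the amide-type nitrogen, whereas this one keeps the aromatic ring there and alters only its substituent, showing that this position can carry benzoyl, with 8 heavy atoms, a second six-membered aromatic ring and a hydrogen-bond acceptor, in place of the 2 heavy atoms of ethyl without any visible shift in the read-out. Nothing available here explains why so large an exchange leaves the reading unmoved.

Still open, on these data alone, is whether an amine or a carboxylic acid on this aromatic carbon would read any differently from ethyl and benzoyl. Also open, as far as these compounds go, is whether benzoyl would leave the reading unchanged on a compound that starts from a higher number, as compound 3 does with 14%, since a start at the bottom of the scale cannot reveal any fall.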